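The source may hold more compounds than are shown below. What is called first, only, known or untested is meant among the compounds shown, and "the series" means these compounds.

Values in a functional assay on KYSE-410 cells (Homo sapiens) for antiproliferative activity, read by MTT assay, with a stated time of 72 h; on this read-out higher numbers stand for weaker inhibition and lower numbers for stronger inhibition:
- compound 1 `O=C(Nc1cccc(F)c1)c1cc(=O)[nH]c2cc(-c3ccc(F)cc3)ccc12`: 10300 nM
- compound 2 `O=C(Nc1cccc(F)c1)c1cc(=O)[nH]c2cc(-c3ccsc3)ccc12`: 4300 nM
- compound 3 `O=C(Nc1cccc(F)c1)c1cc(=O)[nH]c2cc(-c3ccccc3F)ccc12`: > 20000 nM (a limit, not a number)

Compound 3 stands only at a limit of this assay, so it has no exact place in the series. The next compound, compound 4 `Cc1ccc(-c2ccc3c(C(=O)Nc4cccc(F)c4)cc(=O)[nH]c3c2)cc1`, changes the same aromatic carbon of the shared core: 4-methylphenyl in place of 2-fluorophenyl on an aromatic carbon. For the measured compounds named here, no measured step covers this exact exchange, but three steps at this carbon bear on it. Two of them end at compound 3 and give only floors: an at least 1.9-fold higher number from compound 1 to compound 3 (0.28 log units; that floor lies within the scatter) and an at least 4.6-fold higher number from compound 2 to compound 3 (0.66 log units; beyond the scatter). The third, a 2.4-fold lower number from compound 1 to compound 2 (0.38 log units; beyond the scatter), shows that a modest shift can occur between groups at this carbon without reaching a limit. Compound 1 is the closest reference, since its 4-fluorophenyl, like the 4-methylphenyl of compound 4, is a singly substituted six-membered aromatic ring, and compound 1 gives 10300 nM. A modest move toward a lower number in this assay is therefore expected, although a second reading at the limit remains possible. The expected step is an at least 2.2-fold lower number from compound 3 to compound 4 (0.34 log units; beyond the scatter). For compound 4 the estimate is 9000 nM, with an expected range of 3500 nM to 20000 nM.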

Compound 4, half-maximal inhibitory concentration: > 20000 nM
Compound 4: a limit, no number; the forecaster's own chance of this, stated with the estimate: 20%; at least 2.2-fold (0.34 log units) between middle value and limit.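

In this assay compound 4 reads > 20000 nM, a limit and not a number, so a reading at the limit at this aromatic carbon no longer belongs to the 2-fluorophenyl of compound 3 alone. Exchanging thiophen-3-yl for 4-methylphenyl gives an at least 4.6-fold higher number from compound 2 to compound 4 (0.66 log units; beyond the scatter), while methyl in place of fluoro gives an at least 1.9-fold higher number from compound 1 to compound 4 (0.28 log units; that floor lies within the scatter), a floor that does not by itself establish a change between these two phenyl groups. The step from compound 3 to compound 4 cannot be read because both compounds stand at the limit: the limit of > 20000 nM in this assay, at which 2 of the 4 values shown sit.

The compounds shown leave open how far beyond the limit compound 3 and compound 4 lie, and so whether 2-fluorophenyl and 4-methylphenyl differ at all in this assay. Also open, on these data alone, is whether a phenyl group carrying an amine or a carboxylic acid at this carbon, or an unsubstituted phenyl, would return a number rather than a limit in this assay.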